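A few compounds are considered here, and "the series" means these few. Any claim that something is new, unique, unknown or untested is made for them only; others in the source may bear on it.

Measured compounds and their values:
compound 1, `N#Cc1ccc(S(=O)(=O)N[C@H]2CCN(CCCOc3ccc(C(=O)C4CC4)cc3)C2)cc1`, 1600 nM
compound 2, `O=C(c1ccc(OCCCN2CC[C@H](NS(=O)(=O)c3cccc(Cl)c3)C2)cc1)C1CC1`, 700 nM

Compound 1 and compound 2 were compared in an assay on isolated protein for binding affinity to histamine H2 receptor (Homo sapiens); a higher number here means a weaker inhibitor, a lower number a stronger inhibitor. Among the measured compounds shown here, of the two numbers, compound 2 holds the lower one; its nearest neighbour is compound 1, and the one measured step, a 2.3-fold lower number from compound 1 to compound 2 (0.36 log units; beyond the scatter), was brought about by the change from 4-cyanophenyl to 3-chlorophenyl on the sulfonyl sulfur.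

Compound 3, `O=C(c1ccc(OCCCN2CC[C@H](NS(=O)(=O)c3ccc(Cl)cc3)C2)cc1)C1CC1`, has not been measured. It differs from compound 2 in one place: 4-chlorophenyl in place of 3-chlorophenyl on a sulfonyl sulfur. For the measured compounds named here, the only measured step that bears on this change is a 2.3-fold lower number from compound 1 to compound 2 (0.36 log units; beyond the scatter), and it concerns a different exchange, one that swaps both the group and its place on the ring at once, so it offers only loose guidance. Nothing in the two measured compounds separates the effect of the chlorine from the effect of where it sits. The move of chlorine from the 3-position to the 4-position on the phenyl ring is therefore expected to give a step of about a 1.1-fold higher number from compound 2 to compound 3 (0.06 log units; within the scatter) in this assay, that is, no change beyond the scatter in either direction. Compound 3 is accordingly estimated at 800 nM, within a range from 300 nM to 2500 nM.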

Compound 3, inhibition constant: 290 nM
Estimate against measurement, compound 3: 2.8-fold (0.44 log units) above; the whole stated range lies above it.
By their numbers in this assay, from the lowest: compound 3; then compound 2; then compound 1.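

In this assay, the place of the chlorine on the ring matters in its own right: with the same atoms joined differently, 4-chlorophenyl in place of 3-chlorophenyl on the sulfonyl sulfur gives a 2.4-fold lower number from compound 2 to compound 3 (0.38 log units; beyond the scatter) and shows that the two chlorophenyl groups are not interchangeable here. The identity of the group also counts separately, since chloro in place of cyano on an aromatic carbon, with nothing else altered, gives a 5.5-fold lower number from compound 1 to compound 3 (0.74 log units; beyond the scatter) and so isolates an exchange that the earlier step between the 4-cyanophenyl and 3-chlorophenyl compounds had mixed with a change of place. Nothing shown accounts for either step.

The compounds shown leave open whether the lower number belongs to chlorine specifically or would also appear with bromo, fluoro, methyl or methoxy in place of the chloro of the 4-chlorophenyl group. They also leave open whether a cyano group responds to a change of place as chlorine does, and what an unsubstituted phenyl on the sulfonyl sulfur would give in this assay.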